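Benzyl replacing 4-chlorophenyl on the ring nitrogen

The source may hold more compounds than are shown below. What is called first, only, known or untested is meant among the compounds shown, and "the series" means these compounds.

Compound 1 `O=c1sn(-c2ccccc2)c(=O)n1Cc1ccccc1`: 2380 nM in an ADME assay, in phosphate buffer, with a stated time of 30 min, tested at 1 mM, at a dose of 1 mM; on this read-out lower numbers stand for lower exposure and higher numbers for higher exposure at the dose given
Compound 2 `COc1ccc(-n2sc(=O)n(-c3ccc(C)cc3)c2=O)cc1`: < 2000 nM in this assay, a limit
Compound 3 `COc1ccc(-n2sc(=O)n(-c3ccc(Cl)cc3)c2=O)cc1`: < 2000 nM in this assay, a limit

Compound 3 stands only at a limit of this assay, < 2000 nM. Compound 2 likewise stands at a limit, < 2000 nM. The step that the two limits leave unreadable from compound 2 to compound 3 is therefore not readable, as both values sit at the limit of < 2000 nM in this assay, at which 2 of the 3 values shown sit. Compound 1 gives a number, 2380 nM.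

Compound 4 `COc1ccc(-n2sc(=O)n(Cc3ccccc3)c2=O)cc1` differs from compound 3 by benzyl in place of 4-chlorophenyl on an aromatic nitrogen. Going by the values given here, no measured step bears directly on this change. Compound 1 carries the same benzyl group on the ring nitrogen and gives 2380 nM. Compound 4 is therefore expected to lie near compound 1, with the step of an at least 1.1-fold higher number from compound 3 to compound 4 (0.04 log units; that floor lies within the scatter) unreadable against a limit. The estimate for compound 4 is 2200 nM, between 1000 nM and 4500 nM.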

Compound 4, maximal plasma concentration: 5490 nM
Compound 4: middle estimate off by 2.5-fold (0.40 log units), on the low side, outside the stated range (above it).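

Benzyl on the ring nitrogen gives the first readable value in the methoxy-bearing series, with an at least 2.7-fold higher number from compound 3 to compound 4 (0.43 log units; beyond the scatter) and an at least 2.7-fold higher number from compound 2 to compound 4 (0.43 log units; beyond the scatter). Both steps are floors rather than sizes: the limit of < 2000 nM in this assay, at which 2 of the 4 values shown sit.

Methoxy in place of hydrogen on an aromatic carbon also registers once benzyl is present, with a 2.3-fold higher number from compound 1 to compound 4 (0.36 log units; beyond the scatter).

From the compounds shown here alone, the true size of the benzyl step remains open, as does whether the methoxy step holds with 4-chlorophenyl on the ring nitrogen. Whether a longer chain or an amine on that nitrogen would match benzyl is also unresolved.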